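The compounds below may be only part of what the source reports. "The series", "measured", "known", "first", "only" and "open" are said of these compounds alone.

Measured compounds:
Compound 1, `C[C@@H](O[C@H]1CN2C(=O)C=C(c3ccc(NS(C)(=O)=O)cc3)CC2[C@@H]1c1ccc(F)cc1)c1cc(C(F)(F)F)cc(C(F)(F)F)c1`: 1 nM
Compound 2, `C[C@@H](O[C@H]1CN2C(=O)C=C(c3cnn(Cc4ccccc4)c3)CC2[C@@H]1c1ccc(F)cc1)c1cc(C(F)(F)F)cc(C(F)(F)F)c1`: 1.9 nM
Compound 3, `CCc1noc(C2=CC(=O)N3C[C@H](O[C@H](C)c4cc(C(F)(F)F)cc(C(F)(F)F)c4)[C@@H](c4ccc(F)cc4)C3C2)n1`: 0.4 nM

All three compounds were tested in an assay on CHO cells for displacement of a labelled ligand from Substance-P receptor (Homo sapiens) (on this read-out lower numbers stand for stronger inhibition and higher numbers for weaker inhibition), and share one core, differing only in the group on a double-bonded ring carbon of the core. Compound 3 stands lowest of the three numbers: the step of a 2.5-fold lower number from compound 1 to compound 3 (0.40 log units; beyond the scatter) and the step of a 4.8-fold lower number from compound 2 to compound 3 (0.68 log units; beyond the scatter) both lie beyond the scatter, while the step of a 1.9-fold higher number from compound 1 to compound 2 (0.28 log units; within the scatter) does not.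

Compound 4, `C[C@@H](O[C@H]1CN2C(=O)C=C(C3=CCOCC3)CC2[C@@H]1c1ccc(F)cc1)c1cc(C(F)(F)F)cc(C(F)(F)F)c1`, is the next compound to be examined. Its structure differs from compound 3 by a group of 6 heavy atoms (5 carbon, 1 oxygen; one six-membered non-aromatic ring with 1 hetero atom) in place of a group of 7 heavy atoms (4 carbon, 2 nitrogen, 1 oxygen; one five-membered aromatic ring with 3 hetero atoms), on a double-bonded ring carbon. The two measured steps that bear on this change are those at the same position, which replaced one aromatic group by another and moved the number only modestly. For the measured compounds named here, no measured compound carries a non-aromatic group at this position, so the direction is uncertain; the spread of the three known values suggests a change of modest size, and since compound 3 already holds the lowest number, a somewhat higher number for compound 4 is the more likely outcome. Compound 4 is therefore expected to give about 1.5 nM, in a range from 0.5 nM to 5 nM, which would mean an estimated step of a 3.8-fold higher number from compound 3 to compound 4 (0.57 log units; beyond the scatter).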

Compound 4, half-maximal inhibitory concentration: 0.18 nM
Estimate against measurement, compound 4: 8.3-fold (0.92 log units) above; measured number outside the range, below it.
By their numbers in this assay, from the lowest: compound 4; then compound 3; then compounds 1 and 2 (each within the scatter of the next).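

In this assay, the group on the double-bonded ring carbon does not have to be aromatic: the non-aromatic six-membered ring of compound 4 gives a 2.2-fold lower number from compound 3 to compound 4 (0.35 log units; beyond the scatter), as well as a 5.6-fold lower number from compound 1 to compound 4 (0.74 log units; beyond the scatter) and an 11-fold lower number from compound 2 to compound 4 (1.02 log units; beyond the scatter). Compound 4 therefore stands lowest of the four, with its steps to all three others beyond the scatter, and the step from the 1-benzyl-1H-pyrazol-4-yl compound is the only one at this position printed as large. No measurement at hand accounts for this result.

The compounds shown do not separate what the ring oxygen and the double bond of the entering group each contribute, since only this one non-aromatic group appears at this position. A tetrahydropyran-4-yl group, with the double bond gone, or a cyclohexenyl group, with carbon in place of the ring oxygen, would address those two features, and a piperidine ring with its amine nitrogen would show how this position responds to a different ring hetero atom.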